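Swapping Furan for Thiophene in an Adenosine Receptor Series

A few compounds are considered here, and "the series" means these few. Any claim that something is new, unique, unknown or untested is made for them only; others in the source may bear on it.

Of the compounds shown here, three sharing one core have been tested in an assay on membranes from HeLa cells for displacement of a labelled ligand from adenosine receptor A3 (Homo sapiens), read by scintillation counting, with a stated time of 180 min, tested at 1 uM; on this read-out higher numbers stand for more inhibition at the one concentration tested (going by the name of the read-out) and lower numbers for less inhibition. Compound 1 `CCCOC(=O)C1=C(C)NC(=O)NC1c1ccsc1` gives 6%. Within the data shown here, compound 2 `CC1=C(C(=O)OC(C)(C)C)C(c2ccsc2)NC(=O)N1` gives 1%, and the single change between them, tert-butyl in place of propyl on an oxygen next to a carbonyl group, produced a number 5 percentage points lower from compound 1 to compound 2 (within the scatter). Compound 3 `CCN(CC)C(=O)C1=C(C)NC(=O)NC1c1ccoc1` gives 37%, the highest of the three numbers, and its margin over compound 1 as well as over compound 2 lies beyond the usual scatter.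

Compound 4 `CCN(CC)C(=O)C1=C(C)NC(=O)NC1c1ccsc1` differs from compound 3 in one place: thiophen-3-yl in place of furan-3-yl on a saturated ring carbon. Among the measured compounds shown here, no measured step covers this exchange of one five-membered ring for another. For the measured compounds named here, the only measured step, that from compound 1 to compound 2, concerns a group on the other side of the core and says nothing about the ring. Compounds 1 and 2 do carry the thiophen-3-yl ring, but they also carry esters rather than the diethylamide of compound 3, so their lower numbers cannot be laid on the ring alone.

With nothing directly comparable, compound 4 is expected to stay close to compound 3, with a step of a number 7 percentage points lower from compound 3 to compound 4 (within the scatter) in this assay. The estimate for compound 4 is therefore 30%, expected to fall between 12% and 50%.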

Compound 4, a percentage reported as inhibition, at one concentration (the size of the read-out at that concentration, not a potency): 35%
Estimate against measurement, compound 4: 5 percentage points below; the range from low to high includes it.
By their numbers in this assay, from the lowest: compounds 2 and 1 (each within the scatter of the next); then compounds 4 and 3 (each within the scatter of the next).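

In this assay, exchanging furan-3-yl for thiophen-3-yl on the saturated ring carbon gives a number 2 percentage points lower from compound 3 to compound 4 (within the scatter), so with the diethylamino group kept in place, this position accepts either five-membered aromatic ring with no difference that can be told from the scatter. Among these compounds, with the thiophen-3-yl ring now held constant, the group on the carbonyl carbon can be judged on its own for the first time: diethylamino in place of tert-butoxy gives a number 34 percentage points higher from compound 2 to compound 4 (beyond the scatter), and diethylamino in place of propoxy gives a number 29 percentage points higher from compound 1 to compound 4 (beyond the scatter), which ties the higher numbers in this small set to the diethylamino group and not to the ring. Nothing available here offers a reason for any of these steps.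

On these data alone, it remains open whether a phenyl group on the same ring carbon would fit as well as the two five-membered rings, and whether furan-3-yl would also leave the number unchanged in a compound carrying an ester. As far as these compounds go, it is equally open how far the amide can change, for example with dimethylamino or dipropylamino on the carbonyl carbon, and how these single-concentration readings would translate into potency.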